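The source may report more compounds than this note shows. Statements on the series, on what has been measured and on what is new or still open speak of the compounds shown alone.

Working notes on the series. Three members of the shared core have been run in a toxicity assay on THP-1 cells (Homo sapiens) for inhibition; on this read-out higher numbers stand for lower toxicity in this test and lower numbers for higher toxicity in this test: compound 1 `COc1ccc(-c2cnc(NC(=O)c3ccc(F)cc3)n2Cc2ccccc2)cc1`, compound 2 `COc1ccc(-c2cnc(NC(=O)c3ccco3)n2C)cc1` and compound 3 `COc1ccc(-c2cnc(NC(=O)c3ccccc3F)n2C)cc1`. In this assay compound 1 gives only the upper limit of the measurement, > 100000 nM. Compound 2 likewise returns only the limit, > 100000 nM. Compound 3 also stops at the limit, > 100000 nM, so for compound 3 there is a bound and no number in this assay. Every result so far rests at the limit of > 100000 nM in this assay, at which 3 of the 3 values shown sit. Going by the values given here, the one single-point change among the measured compounds, a step that the two limits leave unreadable from compound 2 to compound 3, therefore cannot be sized; the two bounds hide whatever shift the exchange on the carbonyl carbon produced.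

Compound 4 `COc1ccc(-c2cnc(NC(=O)c3ccncc3)n2C)cc1` is the next member, not yet measured in this assay. Its change from compound 3 is pyridin-4-yl in place of 2-fluorophenyl on a carbonyl carbon. Among the compounds with values here, the only measured step that touches the same carbonyl position is the unreadable one from compound 2 to compound 3, and it gives no readable size in either direction. With three limits and no numbered step, no shift beyond the scatter is expected in this assay from this exchange. The expected step is a number no higher from compound 3 to compound 4 (the limit leaves the size open), which is to say none beyond the scatter. Compound 4 is accordingly estimated at 100000 nM, within a range from 30000 nM to 300000 nM, most likely again reported only as the limit.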

Compound 4, half-maximal cytotoxic concentration: > 100000 nM
Compound 4 ended at the assay's limit; the forecaster's own chance of this, stated with the estimate: 85%; the middle value sits exactly at the limit.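

Compound 2, compound 3 and compound 4 all rest at a limit, so no new step can be read in this assay from the exchanges on the carbonyl carbon that lead to compound 4. The compounds shown leave open whether any exchange shifts the read-out in this assay, because every result so far is a bound: the limit of > 100000 nM in this assay, at which 4 of the 4 values shown sit.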